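Chloro for methyl on a hepatoma cell assay

The source may report more compounds than this note shows. Statements on the series, on what has been measured and on what is new or still open speak of the compounds shown alone.

Measured compounds:
compound 1, `Cc1ccc(C2=NN(C3=NC(=O)CS3)C(c3ccc4ccccc4c3)C2)cc1`: 12700 nM
compound 2, `Cc1ccc(C2=NN(C3=NC(c4ccccc4)CS3)C(c3cccc4ccccc34)C2)cc1`: 10400 nM
compound 3, `O=C1CSC(N2N=C(c3ccc(Cl)cc3)CC2c2ccc3ccccc3c2)=N1`: 20400 nM

All three were tested in a functional assay on HepG2 cells (Homo sapiens) for inhibition, read by CCK-8 assay, with a stated time of 48 h; on this read-out higher numbers stand for weaker inhibition and lower numbers for stronger inhibition. In this assay compound 1 gives 12700 nM, compound 3 gives 20400 nM and compound 2 gives 10400 nM. The values of compound 2 and compound 1 lie within the scatter of each other, as do those of compound 2 and compound 3, so no order among the three can be drawn.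

Going by the values given here, the one change measured as a pair is chloro in place of methyl on an aromatic carbon, and it gave a 1.6-fold higher number from compound 1 to compound 3 (0.21 log units; within the scatter). The cores of compound 1 and compound 2 differ in a way that is not broken down here.

Compound 4, `Clc1ccc(C2=NN(C3=NC(c4ccccc4)CS3)C(c3cccc4ccccc34)C2)cc1`, has not yet been measured. It differs from compound 2 by chloro in place of methyl on an aromatic carbon, which is the same change as from compound 1 to compound 3, at the same place. Among the compounds with values here, the expectation for compound 4 therefore rests on the single measured step of the same change, a 1.6-fold higher number from compound 1 to compound 3 (0.21 log units; within the scatter), applied to the value of compound 2, 10400 nM. On that basis the expected step from compound 2 to compound 4 in this assay is a 1.6-fold higher number from compound 2 to compound 4 (0.20 log units; within the scatter). Compound 4 is thus estimated to give about 16500 nM, with a likely range from 7500 nM to 40000 nM.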

Compound 4, half-maximal inhibitory concentration: 18700 nM
Beside the measured number, compound 4's estimate is 1.1-fold (0.05 log units) below it; the measured number falls inside the stated range.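

In this assay, the change from 4-methylphenyl to 4-chlorophenyl on the core of compound 2 gives a 1.8-fold higher number from compound 2 to compound 4 (0.25 log units; within the scatter), and the same change has now been seen on two cores: the same change on two cores in this assay, a 1.6-fold higher number (0.21 log units; within the scatter) from compound 1 to compound 3 and a 1.8-fold higher number (0.25 log units; within the scatter) from compound 2 to compound 4, 1.1-fold (0.05 log units) apart, within the scatter of two such steps

As far as these two pairs can tell, then, the change reads alike on both cores, and a step measured on one core served as a fair guide to the step on the other. This does not show that chloro and methyl truly differ in this assay, as each step taken alone lies within the scatter, and two cores are too few to say that the change would read the same way on a third core.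

The compounds shown leave open how a different kind of group at this place, such as an amine, a carboxylic acid or a longer alkyl chain, would read in this assay, and whether any such group would move the number beyond the scatter. They also leave open which of the differences between the core of compound 1 and the core of compound 2 matter, as those differences are not separated into single changes here.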